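Hydrazone aryl swap at the terminal position of the series

This account rests on a few compounds, and the source may have more. Where it says the series, first, only, none or still open, it means among the compounds named here.

Compound 1 `CN(C)CCn1cnnc1-c1cc(Oc2ccc(NC(=O)N/N=C/c3cccc(O)c3)cc2F)ccn1` carries a 3-hydroxyphenyl on the carbon with a double bond to nitrogen and gives 1370 nM in a functional assay on MKN-45 cells (Homo sapiens) for cytotoxicity, read by MTT assay, with a stated time of 72 h (on this read-out higher numbers stand for weaker inhibition and lower numbers for stronger inhibition), the second highest of the three numbers in hand. Compound 2 `CN(C)CCn1cnnc1-c1cc(Oc2ccc(NC(=O)N/N=C/c3ccc(O)c(O)c3)cc2F)ccn1` gives 3240 nM and compound 3 `CN(C)CCn1cnnc1-c1cc(Oc2ccc(NC(=O)N/N=C/c3c[nH]c4ccccc34)cc2F)ccn1` gives 790 nM. The step of a 2.4-fold higher number from compound 1 to compound 2 (0.37 log units; beyond the scatter) shows that a further hydroxy on the aromatic ring weakens inhibition modestly, while the step of a 1.7-fold lower number from compound 1 to compound 3 (0.24 log units; within the scatter) stays within the scatter and a 4.1-fold lower number from compound 2 to compound 3 (0.61 log units; beyond the scatter) is again modest.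

Compound 4 `CN(C)CCn1cnnc1-c1cc(Oc2ccc(NC(=O)N/N=C/c3ccc(F)cc3)cc2F)ccn1` differs from compound 1 as follows: 4-fluorophenyl in place of 3-hydroxyphenyl on a carbon with a double bond to nitrogen. Going by the values given here, two measured steps bear on it. Removing the single hydroxy runs opposite to the step from compound 1 to compound 2, which would point to a lower number; replacing the 3-hydroxyphenyl by a group without donors or acceptors resembles the step to compound 3, which stayed within the scatter. Taken together a small drop in the number, at the edge of the scatter, is expected, so that a 1.5-fold lower number from compound 1 to compound 4 (0.18 log units; within the scatter) is the estimated step. Compound 4 is therefore expected to give about 900 nM in this assay, with a likely range from 400 nM to 2500 nM.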

Compound 4, half-maximal inhibitory concentration: 1030 nM
The estimate for compound 4 lay 1.1-fold (0.06 log units) below the measured number; the range from low to high includes it.
By their numbers in this assay, from the lowest: compounds 3, 4 and 1 (each within the scatter of the next); then compound 2.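

In this assay, the exchange gives a 1.3-fold lower number from compound 1 to compound 4 (0.12 log units; within the scatter), so on the carbon with a double bond to nitrogen, 4-fluorophenyl, with 0 hydrogen-bond donors and 0 hydrogen-bond acceptors, cannot be told apart from 3-hydroxyphenyl, with 1 of each. The comparison with the indole gives a 1.3-fold higher number from compound 3 to compound 4 (0.12 log units; within the scatter), also within the scatter, so 4-fluorophenyl and 1H-indol-3-yl cannot be separated here either, and compounds 1, 3 and 4 form one group despite their different aryl groups. Against this group, a 3.1-fold lower number from compound 2 to compound 4 (0.50 log units; beyond the scatter) is beyond the scatter, which adds a third modest step to those already seen from compound 2 and leaves the 3,4-dihydroxyphenyl group as the only one of the four that stands apart, while the single hydroxy of compound 1 does not set it apart from compound 4.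

No measurement at hand gives a reason for these differences.

Going by these compounds, how a phenyl ring carrying a carboxylic acid or a dimethylamino group would compare on this carbon remains open, as does whether a single hydroxy at the 4-position of the phenyl ring would behave like 3-hydroxyphenyl or like 3,4-dihydroxyphenyl.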